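This account rests on a few compounds, and the source may have more. Where it says the series, first, only, none or still open, it means among the compounds named here.

Compound 1 `CCCCNc1nc(N)nc2c1CN(Cc1ccccc1)CC2` is the starting point. In an assay on HEK293 cells for agonist activity at Toll-like receptor 8 (Homo sapiens), read by a luciferase reporter, with a stated time of 6 h (a lower number here means that less compound is needed, a higher number that more compound is needed for the effect), compound 1 gives 0.06 uM, the highest of the two numbers in hand; its nearest neighbour is compound 2 `CCCCNc1nc(N)nc2c1CN(C)CC2`, which in this assay gives 0.03 uM. Among the compounds with values here, the one measured step, a 2.0-fold lower number from compound 1 to compound 2 (0.30 log units; within the scatter), arises from hydrogen in place of phenyl on a saturated chain carbon bound to an amine nitrogen in a ring. Compound 3 `CCCCNc1nc(N)nc2c1CN(Cc1ccc(C(C)(C)C)cc1)CC2` keeps the phenyl of compound 1 and adds to it: tert-butyl in place of hydrogen on an aromatic carbon. The measured step concerns removing the whole phenyl, not decorating it, so it bears on this change only loosely; since even that removal stayed within the scatter, a tert-butyl added to the retained phenyl is expected to move the number little, if at all, so the estimated step is a 1.3-fold higher number from compound 1 to compound 3 (0.12 log units; within the scatter). For compound 3 the expected value is 0.08 uM, within a range from 0.02 uM to 0.3 uM.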

Compound 3, minimum effective concentration: 0.66 uM
Estimate against measurement, compound 3: 8.3-fold (0.92 log units) below, and the stated range ends below it.
By their numbers in this assay, from the lowest: compounds 2 and 1 (each within the scatter of the next); then compound 3.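

The phenyl of compound 1 turns out to be sensitive to what it carries: in this assay, tert-butyl on an aromatic carbon of this ring, para to a large group, gives an 11-fold higher number from compound 1 to compound 3 (1.04 log units; beyond the scatter), so much more compound is needed for the effect. The earlier pair, with a 2.0-fold lower number from compound 1 to compound 2 (0.30 log units; within the scatter), showed only that removing the whole phenyl stays within the scatter, whereas this result shows that adding to the retained ring can move the number further than removing the ring does. Nothing measured here gives a reason for this rise.

From the compounds shown here alone, whether this holds only for tert-butyl stays open: a methyl group, a chlorine atom, an amine or a carboxylic acid on the same aromatic carbon could read quite differently. The compounds shown also leave open how a group on another carbon of this ring would read.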